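The source may hold more compounds than are shown below. What is called first, only, known or untested is meant among the compounds shown, and "the series" means these compounds.

Series notes. Compound 1 `COc1ccc(Sc2ccccc2N2CCN(CC(=O)O)C(C)C2)cc1` gives 1700 nM in an assay for inhibition of sodium- and chloride-dependent glycine transporter 1 (Homo sapiens); on this read-out lower numbers stand for stronger inhibition and higher numbers for weaker inhibition. Compound 2 `COc1ccc(Sc2ccccc2N2CCN(CC(=O)O)C(C)(C)C2)cc1` carries methyl in place of hydrogen on a saturated ring carbon and gives 1500 nM; the step of a 1.1-fold lower number from compound 1 to compound 2 (0.05 log units; within the scatter). Compound 3 `COc1ccc(Sc2ccc(OC)cc2N2CCN(CC(=O)O)C(C)C2)cc1` gives 4600 nM; relative to the core of compound 1 it carries methoxy in place of hydrogen on an aromatic carbon, and the step of a 2.7-fold higher number from compound 1 to compound 3 (0.43 log units; beyond the scatter). Compound 4 `COc1ccc(Sc2ccc(OC)cc2N2CC(C)N(CC(=O)O)CC2C)cc1`, not yet measured, is compound 3 with methyl in place of hydrogen on a saturated ring carbon. This is the same kind of change as from compound 1 to compound 2, not the same: in compound 2 the methyl sits next to the ring atom that bears a carboxymethyl group and two ring bonds from the ring atom that bears a large group, whereas in compound 4 it sits next to the ring atom that bears a large group, two ring bonds from the ring atom that bears a carboxymethyl group and three ring bonds from the ring atom that bears a methyl group. Because the step of a 1.1-fold lower number from compound 1 to compound 2 (0.05 log units; within the scatter) lay within the scatter, a similarly small step is expected here, a 1.0-fold lower number from compound 3 to compound 4 (0.01 log units; within the scatter), with added uncertainty from the different place. Compound 4 is expected at 4500 nM, between 2000 nM and 10000 nM.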

Compound 4, half-maximal inhibitory concentration: > 50000 nM
Compound 4: a limit, no number; the forecaster's own chance of this, stated with the estimate: 5%; middle value at least 11-fold (1.04 log units) from the limit.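

In this assay compound 4 gives > 50000 nM, which is a limit of the assay and not a number. Methyl in place of hydrogen on a saturated ring carbon gives an at least 10-fold higher number from compound 3 to compound 4 (1.03 log units; beyond the scatter), and the change does not carry over from one core to the other with a like size: the same change on two cores in this assay, a 1.1-fold lower number (0.05 log units; within the scatter) from compound 1 to compound 2 and an at least 10-fold higher number (1.03 log units; beyond the scatter) from compound 3 to compound 4, at least 12-fold (1.09 log units) apart, beyond the scatter of two such steps The methyl of compound 4 also sits in a different place from that of compound 2, next to the ring atom that bears a large group, so this comparison does not separate the core from the place, and the limit leaves the full size of the step unfixed.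

Open, from the compounds shown here alone, is whether a methyl in that place has a like result on the core of compound 1. Also open, going by these compounds, is how an amine or a longer carboxylic acid chain in place of the carboxymethyl group would read out in this assay.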